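This account rests on a few compounds, and the source may have more. Where it says the series, first, only, none or still open, it means among the compounds named here.

Values in a functional assay on A2780 cells (Homo sapiens) for inhibition, read by sulforhodamine B assay; a higher number here means a weaker inhibitor of growth, a lower number a stronger inhibitor of growth:
- compound 1 `FC(F)(F)Oc1ccc(-c2ccc(-c3ccc(-c4nc5ccccc5[nH]4)cc3)cc2)cc1`: 100000 nM
- compound 2 `Oc1ccc(-c2ccc(-c3ccc(-c4nc5ccccc5[nH]4)cc3)cc2)cc1`: 36000 nM
- compound 3 `COc1ccc(-c2ccc(-c3ccc(-c4nc5ccccc5[nH]4)cc3)cc2)cc1`: 100000 nM

Compound 1 gives 100000 nM, level with compound 3 at the digits shown, and these two share the highest number of the three. Only compound 2 departs from them, with a 2.8-fold lower number from compound 1 to compound 2 (0.44 log units; beyond the scatter).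

The next compound is compound 4 `Oc1cccc2[nH]c(-c3ccc(-c4ccc(-c5ccc(OC(F)(F)F)cc5)cc4)cc3)nc12`, which has hydroxy in place of hydrogen on an aromatic carbon. The same difference reads as 1H-benzimidazol-2-yl to 4-hydroxy-1H-benzimidazol-2-yl.

Among the compounds with values here, no measured step changes this place, so the evidence is indirect. The three measured steps all alter the group on an oxygen on an aromatic ring: a 2.8-fold lower number from compound 1 to compound 2 (0.44 log units; beyond the scatter), a 2.8-fold higher number from compound 2 to compound 3 (0.44 log units; beyond the scatter) and no change at the digits printed from compound 1 to compound 3 (within the scatter). They show that, among these three compounds, the free hydroxy of compound 2 goes with the lowest number, 36000 nM. Carried over to the new place, this suggests a modest lowering in this assay of about that size, though with wide uncertainty, and no change beyond the scatter remains possible.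

The expected change is a 2.9-fold lower number from compound 1 to compound 4 (0.46 log units; beyond the scatter). For compound 4 the estimated value is 35000 nM, with an expected range of 6000 nM to 100000 nM.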

Compound 4, concentration for 50% growth inhibition: 2900 nM
Beside the measured number, compound 4's estimate is 12-fold (1.08 log units) above it; the measured number lies below the stated range.
By their numbers in this assay, from the lowest: compound 4; then compound 2; then compounds 1 and 3 (each within the scatter of the next).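

In this assay, replacing 1H-benzimidazol-2-yl with 4-hydroxy-1H-benzimidazol-2-yl gives a 34-fold lower number from compound 1 to compound 4 (1.54 log units; beyond the scatter), showing that this aromatic carbon of the fused ring system is a place where a single hydroxy can shift growth inhibition by a large margin. The three earlier compounds varied only the group on the oxygen at the other end of the molecule, where the largest change was the modest 2.8-fold lower number from compound 1 to compound 2 (0.44 log units; beyond the scatter), so they gave no sign that the series could move this far in this assay from compound 1. No measurement shown here bears on why this hydroxy has so large an effect.

With only hydrogen and hydroxy shown at this place, it remains open whether the step is specific to hydroxy or would also appear with a methoxy, an amine or a fluorine on the same carbon, or with hydroxy on another carbon of that ring. Within the data shown here, it is also open whether the step depends on the trifluoromethyl on the far oxygen, since a single pair defines it and no pair shows this hydroxy with a methyl or hydrogen on that oxygen.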